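This account rests on a few compounds, and the source may have more. Where it says the series, first, only, none or still open, it means among the compounds named here.

The measured compounds:
Compound 1 `O/N=C(/Nc1ccc(Cl)cc1)c1ccc2occc2c1` reaches only a limit, > 30000 nM, in an assay on tissue (HeLa cells) for inhibition of Indoleamine 2,3-dioxygenase 1 (Homo sapiens), read by spectrophotometry; on this read-out higher numbers stand for weaker inhibition and lower numbers for stronger inhibition.
Compound 2 `O/N=C(/Nc1cccc(F)c1)c1ccc2occc2c1` gives 20000 nM in this assay.
Compound 3 `O/N=C(/Nc1ccc(F)c(F)c1)c1ccc2occc2c1` gives 14000 nM in this assay.

For compound 1 the result is a limit of the assay rather than a number (the limit of > 30000 nM in this assay, at which 1 of the 3 values shown sits). Of the two actual numbers, compound 3 holds the lower one, and compound 2 sits close to it: the step of a 1.4-fold lower number from compound 2 to compound 3 (0.15 log units; within the scatter) stays within the scatter, so no order can be read between compound 2 and compound 3.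

Compound 4 `O/N=C(/Nc1ccc(F)c(Br)c1)c1ccc2occc2c1` differs from compound 3 in one place: bromo in place of fluoro on an aromatic carbon. For the measured compounds named here, no measured step exchanges one halogen for another. Going by the values given here, the only measured step, a 1.4-fold lower number from compound 2 to compound 3 (0.15 log units; within the scatter), adds a fluoro where there was hydrogen and stays within the scatter, so it gives little guidance on swapping fluoro for bromo. Compound 1, which carries a chloro instead, only reaches a limit and adds no number to lean on. The expected step from compound 3 to compound 4 in this assay is therefore none beyond the scatter, estimated as a 1.2-fold lower number from compound 3 to compound 4 (0.07 log units; within the scatter). Compound 4 is expected to give about 12000 nM, within a range from 4000 nM to 40000 nM.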

Compound 4, half-maximal inhibitory concentration: 2600 nM
Compound 4: the middle estimate sits 4.6-fold (0.66 log units) above what was measured, outside the stated range (below it).
By their numbers in this assay, from the lowest: compound 4; then compounds 3 and 2 (each within the scatter of the next). At a limit, above all of these: compound 1.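

In this assay this place on the ring does respond to the choice of halogen: on an aromatic carbon ortho to a fluoro group and meta to a large group, putting bromo in place of fluoro gives a 5.4-fold lower number from compound 3 to compound 4 (0.73 log units; beyond the scatter) and so a modest gain in inhibition, with one heavy atom exchanged for one and no hydrogen-bond donors or acceptors added. For the compounds shown here, the earlier measured step, a 1.4-fold lower number from compound 2 to compound 3 (0.15 log units; within the scatter), changed a different carbon of the ring and left this place untouched, so this is the first step that reads on this position and the first to clear the scatter. The measurements shown carry no information on why bromo gives the lower number here.

On these data alone, it stays open whether the gain follows from bromo alone or needs the fluoro group that stays on the neighbouring part of the ring in both compounds, a question that a version of compound 4 with hydrogen in place of that fluoro would address. As far as these compounds go, it also stays open how a methyl, a methoxy or a nitrile would behave at this same place on the shared core.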